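A few compounds are considered here, and "the series" means these few. Any claim that something is new, unique, unknown or untested is made for them only; others in the source may bear on it.

Measured compounds:
- Compound 1 `O=C(Nc1ccc(Oc2cc(C(F)(F)F)cc(C(F)(F)F)c2)cc1)c1cc(Cl)ccc1F`: 1110 nM
- Compound 2 `O=C(Nc1ccc(Oc2cc(C(F)(F)F)cc(C(F)(F)F)c2)cc1)c1c(F)cccc1C(F)(F)F`: "not determined" (no result reported)
- Compound 3 `O=C(Nc1ccc(Oc2cc(C(F)(F)F)cc(C(F)(F)F)c2)cc1)c1c(O)cccc1F`: "not determined" (no result reported)

The three compounds share one core and differ only in the benzamide portion. Going by the values given here, in an assay on HEK293 cells for inhibition of Toll-like receptor 8 (Homo sapiens), with a stated time of 16 h (on this read-out lower numbers stand for stronger inhibition and higher numbers for weaker inhibition), compound 1 gives 1110 nM and is the only compound with a number. In this assay, among the compounds with values here, compound 2 gives "not determined" (no result reported) and compound 3 gives "not determined" (no result reported), so compound 3 stands without any value, and there is no step between measured compounds on which to lean.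

Compound 4 `O=C(Nc1ccc(Oc2cc(C(F)(F)F)cc(C(F)(F)F)c2)cc1)c1c(F)cccc1OC(F)(F)F` is derived from compound 3 by the change (trifluoromethyl in place of hydrogen on an oxygen on an aromatic ring), that is, trifluoromethyl in place of hydrogen on an oxygen on an aromatic ring, read one bond further out as hydroxy to trifluoromethoxy. Within the data shown here, with no number for compound 3 and no comparable step among the measured compounds, the size and direction of this step in this assay cannot be read from the data; no step beyond the scatter is asserted either way.

Compound 4 is therefore expected to land near compound 1, with an estimated value of 1500 nM and a likely range from 400 nM to 6000 nM, the breadth reflecting the lack of any anchoring measurement for compound 3.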

Compound 4, half-maximal inhibitory concentration: > 50000 nM
Compound 4 was reported as a limit; the forecaster's own chance of this, stated with the estimate: 20%; middle value at least 33-fold (1.52 log units) away from the limit.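

In this assay compound 4 gives no number but a limit of the assay: the limit of > 50000 nM in this assay, at which 1 of the 4 values shown sits.

The earlier compounds shown here offered a single value and so showed nothing about how far the benzamide portion can move this read-out. Replacing that portion on the carbonyl carbon now gives an at least 45-fold higher number from compound 1 to compound 4 (1.65 log units; beyond the scatter), so a change in this place alone can carry a compound beyond the scatter, and the trifluoromethoxy compound lies on the weak side of compound 1.

Steps involving compound 2 or compound 3 cannot be read, which leaves open how much of this gap belongs to the change from hydroxy to trifluoromethoxy itself. Also open, on these data alone, is how methyl or a longer alkyl chain on an oxygen on an aromatic ring would read in this assay.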